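Replacing a naphthyl arm with a chlorobenzyl arm

This account rests on a few compounds, and the source may have more. Where it says the series, first, only, none or still open, it means among the compounds named here.

Measured compounds:
compound 1 `O=S(=O)(NCCCNCC1COc2ccccc2O1)c1cc(C(F)(F)F)cc(C(F)(F)F)c1` 3400 nM
compound 2 `O=S(=O)(NCCCNCc1ccccc1)c1cc(C(F)(F)F)cc(C(F)(F)F)c1` 16000 nM
compound 3 `O=S(=O)(NCCCNCc1cccc2ccccc12)c1cc(C(F)(F)F)cc(C(F)(F)F)c1` 2700 nM

In a functional assay on PANC-1 cells (Homo sapiens) for inhibition, read by MTT assay, with a stated time of 72 h (on this read-out lower numbers stand for stronger inhibition of growth and higher numbers for weaker inhibition of growth), compound 3 gives the lowest of the three numbers. Its nearest neighbour is compound 1, and the gap a 1.3-fold lower number from compound 1 to compound 3 (0.10 log units; within the scatter) lies within the scatter, so the two cannot be ordered. The furthest is compound 2, separated by a 5.9-fold lower number from compound 2 to compound 3 (0.77 log units; beyond the scatter). The unmeasured compound 4 `O=S(=O)(NCCCNCc1ccc(Cl)cc1)c1cc(C(F)(F)F)cc(C(F)(F)F)c1` differs from compound 3 by 4-chlorophenyl in place of naphthalen-1-yl on a saturated chain carbon bound to an amine nitrogen.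

Going by the values given here, two measured steps bear on this change. The step of a 5.9-fold lower number from compound 2 to compound 3 (0.77 log units; beyond the scatter) shows that a naphthalen-1-yl group gives a modestly lower number than a plain phenyl on the same chain carbon, and the step of a 4.7-fold higher number from compound 1 to compound 2 (0.67 log units; beyond the scatter) shows phenyl again at the high end. Among the compounds with values here, compound 4 carries a single ring with a chlorine, which sits closer to compound 2 than to compound 3 in shape, yet no measured pair tells what the chlorine adds. The expectation is therefore a modest rise from compound 3, short of the full distance back to compound 2, so that for compound 4 the expected step is a 3.0-fold higher number from compound 3 to compound 4 (0.47 log units; beyond the scatter). In this assay compound 4 is expected to give about 8000 nM, with a range from 3000 nM to 20000 nM.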

Compound 4, concentration for 50% growth inhibition: 4900 nM
Estimate against measurement, compound 4: 1.6-fold (0.21 log units) above; the range from low to high includes it.
By their numbers in this assay, from the lowest: compounds 3, 1 and 4 (each within the scatter of the next); then compound 2.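

In this assay, going by these compounds alone, chloro in place of hydrogen on an aromatic carbon gives a 3.3-fold lower number from compound 2 to compound 4 (0.51 log units; beyond the scatter), the first measured step in which a single atom is changed on this arm, and it is beyond the scatter. The single ring therefore does not stay at the high end once it carries the chlorine: the 4-chlorophenyl arm cannot be told apart from the naphthalen-1-yl arm, with a 1.8-fold higher number from compound 3 to compound 4 (0.26 log units; within the scatter), or from the 2,3-dihydro-1,4-benzodioxin-2-yl arm, with a 1.4-fold higher number from compound 1 to compound 4 (0.16 log units; within the scatter), both within the scatter. Among these four compounds, a second ring on the saturated chain carbon bound to an amine nitrogen is thus not needed to reach this level, and only compound 2 stands apart; nothing measured here accounts for the shift that the chlorine brings.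

On these data alone, it remains open whether this shift is particular to chlorine or would also appear with a fluorine, a methyl, a methoxy or a nitrile on the same ring. Also open, as far as these compounds go, is how a carboxylic acid or an amine on that ring, or a longer chain carrying it, would read in this assay.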